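Second Fluorine on the Fluorobenzyl Group

The compounds below may be only part of what the source reports. "The series", "measured", "known", "first", "only" and "open" are said of these compounds alone.

Three hydroxamic acids sharing one core were tested in an assay on isolated protein for inhibition of protein deacetylase HDAC6 (Homo sapiens), read by fluorescence, with a stated time of 1 h, tested at 100 nM; on this read-out lower numbers stand for less inhibition and higher numbers for more inhibition at the one concentration tested (going by the name of the read-out). Compound 1 `CCCN1CCC(c2noc(COc3ccc(/C=C/C(=O)NO)cc3)n2)CC1` gives 69%, compound 2 `C=CCN1CCC(c2noc(COc3ccc(/C=C/C(=O)NO)cc3)n2)CC1` gives 66%, and compound 3 `O=C(/C=C/c1ccc(OCc2nc(C3CCN(Cc4ccccc4F)CC3)no2)cc1)NO` gives 68%. The three steps that vary the group on the saturated chain carbon bound to the amine nitrogen in the ring were all small: a number 3 percentage points lower from compound 1 to compound 2 (within the scatter), a number 1 percentage points lower from compound 1 to compound 3 (within the scatter) and a number 2 percentage points higher from compound 2 to compound 3 (within the scatter). Compound 3 thus sits among numbers that cannot be told apart.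

Compound 4 `O=C(/C=C/c1ccc(OCc2nc(C3CCN(Cc4ccc(F)cc4F)CC3)no2)cc1)NO` differs from compound 3 by fluoro in place of hydrogen on an aromatic carbon, 2-fluorophenyl to 2,4-difluorophenyl. Within the data shown here, no measured step adds a fluoro to an aromatic carbon, so the three small steps bear only indirectly. A step of no change at the digits printed from compound 3 to compound 4 (within the scatter) is expected, none beyond the scatter, and compound 4 is estimated at 68% with a range of 57% to 79%.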

Compound 4, a percentage reported as inhibition, at one concentration (the size of the read-out at that concentration, not a potency): 74%
Estimate against measurement, compound 4: 6 percentage points below; measured number inside the range.
By their numbers in this assay, from the lowest: compounds 2, 3, 1 and 4 (each within the scatter of the next).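

A second fluoro on the aromatic carbon, meta to a fluoro group and para to a large group, gives a number 6 percentage points higher from compound 3 to compound 4 (within the scatter) in this assay, so this first test of the position shows no change that can be told from scatter. Against the smaller chain groups, 2,4-difluorophenyl also stays inside the scatter, with a number 8 percentage points higher from compound 2 to compound 4 (within the scatter) and a number 5 percentage points higher from compound 1 to compound 4 (within the scatter) as the remaining steps. Nothing available bears on a cause for these numbers. Open, as far as these compounds go, is whether a chloro or methoxy group at this aromatic carbon would read differently, and whether an amine there would.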